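The compounds below may be only part of what the source reports. "The series", "measured", "known", "first", "only" and "open" are said of these compounds alone.

Measured compounds in a functional assay on SiHa cells (Homo sapiens) for cytotoxicity, read by MTT assay, with a stated time of 48 h; a higher number here means a weaker inhibitor, a lower number a stronger inhibitor:
Compound 1, `CCCCCCCCNC(=O)[C@@H](NC(=O)c1cccs1)[C@@H](C)O`, gives 91900 nM.
Compound 2, `CCCCCCCCNC(=O)[C@@H](NC(=O)c1cc2ccccc2o1)[C@@H](C)O`, gives 66500 nM.
Compound 3, `C/C=C/C=C/C(=O)N[C@H](C(=O)NCCCCCCCC)[C@@H](C)O`, gives 123000 nM.

Compound 2 has the lowest of the three numbers in this assay, but its nearest neighbour, compound 1, sits within the scatter of it (a 1.4-fold lower number from compound 1 to compound 2 (0.14 log units; within the scatter)), as does compound 3 (a 1.8-fold higher number from compound 2 to compound 3 (0.27 log units; within the scatter)), and the step of a 1.3-fold higher number from compound 1 to compound 3 (0.13 log units; within the scatter) is likewise within the scatter. The three measured compounds therefore do not separate from one another.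

Compound 4, `CCCCCCCCCCCCCCNC(=O)[C@@H](NC(=O)c1cc2ccccc2o1)[C@@H](C)O`, differs from compound 2 in one place: hexyl in place of hydrogen on a saturated chain carbon, eight bonds along the chain from an amide-type nitrogen. Every measured step changes the acyl group on the carbonyl carbon; none touches the saturated chain on the amide nitrogen. Going by the values given here, no measured step therefore bears on this change, and the data give no direction for it. The expectation for compound 4 is thus simply a number close to that of compound 2, with a wide range: compound 4 is estimated at 50000 nM, between 15000 nM and 150000 nM, which means an expected step of a 1.3-fold lower number from compound 2 to compound 4 (0.12 log units; within the scatter).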

Compound 4, half-maximal inhibitory concentration: 14200 nM
For compound 4 the middle estimate is 3.5-fold (0.55 log units) above the measured one; the whole stated range lies above it.
By their numbers in this assay, from the lowest: compound 4; then compounds 2, 1 and 3 (each within the scatter of the next).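

In this assay the saturated chain on the amide nitrogen proves to be a place where the number moves: hexyl in place of hydrogen on a saturated chain carbon gives a 4.7-fold lower number from compound 2 to compound 4 (0.67 log units; beyond the scatter) and so stands apart from the changes to the acyl group, all of which stayed within the scatter. This is the first step among these compounds to lie beyond the scatter, though it rests on a single pair, with the 1-benzofuran-2-yl group held fixed. Nothing given here accounts for the lower number that comes with the added hexyl.

As far as these compounds go, it remains open whether the same change would lower the number with thiophen-2-yl or penta-1,3-dien-1-yl on the carbonyl carbon. From the compounds shown here alone, it is also open whether a still longer chain would lower it further, or how a chain ending in an amine or a carboxylic acid would compare.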